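Cyclopropyl for Neopentyl on the Amine of Compound 3

A few compounds are considered here, and "the series" means these few. Any claim that something is new, unique, unknown or untested is made for them only; others in the source may bear on it.

Compound 3 `CC(C)(C)CNCc1ccc2c(c1)CCC[C@H]2NC(=O)C[C@@H]1CCCCN1S(=O)(=O)c1cccc(C(F)(F)F)c1` gives 59 nM in an assay on isolated protein for inhibition of B1 bradykinin receptor (Homo sapiens) (on this read-out lower numbers stand for stronger inhibition and higher numbers for weaker inhibition), the lowest of the three numbers recorded. Compound 1 `CC(C)(C)NCc1ccc2c(c1)CCC[C@H]2NC(=O)C[C@@H]1CCCCN1S(=O)(=O)c1ccc(Cl)cc1` gives 560 nM in this assay, and compound 2 `COc1ccc(S(=O)(=O)N2CCCC[C@H]2CC(=O)N[C@@H]2CCCc3cc(CNC(C)(C)C)ccc32)cc1` gives 780 nM in this assay; the distance from compound 3 to each of them lies beyond the scatter. Among the measured compounds shown here, the only measured step with a single change, a 1.4-fold higher number from compound 1 to compound 2 (0.14 log units; within the scatter), concerns a substituent on an aromatic carbon and says nothing about the amine. Compound 4 `O=C(C[C@@H]1CCCCN1S(=O)(=O)c1cccc(C(F)(F)F)c1)N[C@@H]1CCCc2cc(CNC3CC3)ccc21` differs from compound 3 by cyclopropyl in place of neopentyl on an amine nitrogen. For the measured compounds named here, no measured pair isolates a change at that amine nitrogen: compound 1 and compound 3 differ there and in a second place at once, so their two values cannot be apportioned. The expectation therefore rests on the rest of the molecule being unchanged and on the absence of any precedent pointing in either direction, which argues for a modest move at most. More room is left on the weaker side, since the nearest reference point, compound 3 with 59 nM, is already the lowest number seen. Compound 4 is expected to give about 120 nM in this assay, within 40 nM to 400 nM. The expected step is a 2.0-fold higher number from compound 3 to compound 4 (0.31 log units; beyond the scatter).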

Compound 4, half-maximal inhibitory concentration: 48 nM
Estimate against measurement, compound 4: 2.5-fold (0.40 log units) above; low and high end bracket the measured number.
By their numbers in this assay, from the lowest: compounds 4 and 3 (each within the scatter of the next); then compounds 1 and 2 (each within the scatter of the next).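

Among the compounds shown here, the change from neopentyl to cyclopropyl on this amine nitrogen is the first single change at this position that can be read, and in this assay it gives a 1.2-fold lower number from compound 3 to compound 4 (0.09 log units; within the scatter). A group of 5 heavy atoms with no ring thus gives way to one of 3 heavy atoms in a three-membered ring, with no change in the count of hydrogen-bond donors or acceptors and no difference that the measurement can separate from the scatter, so for this pair, with the rest of the molecule held constant, the open chain and the small ring read alike. No measured evidence explains why the two groups read alike.

The compounds shown leave open whether a cyclobutyl group, a longer chain or a bare hydrogen on this nitrogen would stay in the same range, since this single pair marks no limit to what the position accepts. Also open, going by these compounds, is how much of the gap between compound 1 and compound 3 belongs to the amine, as these two compounds still differ in two places at once.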